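This account rests on a few compounds, and the source may have more. Where it says the series, first, only, none or still open, it means among the compounds named here.

In a functional assay on A549 cells (Homo sapiens) for inhibition, read by sulforhodamine B assay, with a stated time of 72 h (on this read-out higher numbers stand for weaker inhibition and lower numbers for stronger inhibition), compound 1 (`C#Cc1cccc(Nc2ncnc3cc(OCCCCCn4ccnc4[N+](=O)[O-])c(OC)cc23)c1`) gives 180 nM and compound 2 (`COc1cc2c(Nc3cccc(Br)c3)ncnc2cc1OCCCCn1ccnc1[N+](=O)[O-]`) gives 1970 nM as the higher of the two numbers, a gap beyond the scatter. Compound 3 (`COc1cc2c(Nc3cccc(Br)c3)ncnc2cc1OCCCCCn1ccnc1[N+](=O)[O-]`) departs from compound 2 by one change ((2-nitro-1H-imidazol-1-yl)methyl in place of 2-nitro-1H-imidazol-1-yl on a saturated chain carbon, four bonds along the chain from an oxygen on an aromatic ring) which places (2-nitro-1H-imidazol-1-yl)methyl in place of 2-nitro-1H-imidazol-1-yl on a saturated chain carbon, four bonds along the chain from an oxygen on an aromatic ring. Among the compounds with values here, no measured step yet shows the effect of this change, so guidance is thin. Within the data shown here, a moderate move to a lower number in this assay is expected, near the edge of the scatter, with compound 1 at 180 nM as the only sign that lower numbers occur. The estimate amounts to a 2.2-fold lower number from compound 2 to compound 3 (0.34 log units; beyond the scatter) as the expected step. For compound 3 the estimated value is 900 nM (expected range 250 nM to 2800 nM).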

Compound 3, half-maximal inhibitory concentration: 8420 nM
For compound 3 the middle estimate is 9.4-fold (0.97 log units) below the measured one; the measured number lies above the stated range.
By their numbers in this assay, from the lowest: compound 1; then compound 2; then compound 3.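

In this assay, within the data shown here, the change to (2-nitro-1H-imidazol-1-yl)methyl on the saturated chain carbon gives a 4.3-fold higher number from compound 2 to compound 3 (0.63 log units; beyond the scatter) and so provides the first reading of chain length, with the added carbon moving the number up rather than down. With that chain held fixed, bromo in place of ethynyl on an aromatic carbon gives a 47-fold higher number from compound 1 to compound 3 (1.67 log units; beyond the scatter) as a clearly larger step than the chain change, so the aromatic substituent carries more of the spread in this pair than the chain does in the other. No supporting data account for either step.

A single pair cannot show whether the chain step holds when ethynyl sits on the aromatic carbon. As far as these compounds go, how a longer chain, or an amine in place of the 2-nitro-1H-imidazol-1-yl group, would read also stays open.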